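Swapping a Fluoropyridine for a Methylphenyl Group

The source may hold more compounds than are shown below. What is called first, only, known or untested is meant among the compounds shown, and "the series" means these compounds.

Compound 1, `CCc1cc(Nc2nc(N[C@@H](C)c3ccc(F)cn3)nc3cccc(C)c23)n[nH]1`: 11 nM
Compound 2, `CCc1cc(Nc2nc(N[C@@H](C)c3ccc(F)cn3)nc3cccc(F)c23)n[nH]1`: 29 nM

Both compounds were tested in an assay on isolated protein for inhibition of G protein-coupled receptor kinase 6 (Homo sapiens), read by scintillation counting, radiometric assay and 33P incorporation, with a stated time of 80 min, in the presence of a further agent that is not named here; on this read-out lower numbers stand for stronger inhibition and higher numbers for weaker inhibition. In that test compound 1 gives 11 nM, and compound 2 gives 29 nM. Within the data shown here, compound 2 therefore holds the higher of the two numbers, and the single step that joins the pair, a 2.6-fold higher number from compound 1 to compound 2 (0.42 log units; beyond the scatter), lies beyond the usual scatter, so the difference is real if modest.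

Compound 3, `CCc1cc(Nc2nc(N[C@@H](C)c3ccc(C)cc3)nc3cccc(F)c23)n[nH]1`, has not yet been measured. It differs from compound 2 in one place: 4-methylphenyl in place of 5-fluoropyridin-2-yl on a saturated chain carbon bound to a nitrogen on an aromatic ring and a saturated chain carbon. Among the measured compounds shown here, the part of the molecule that was altered between compound 1 and compound 2 is left unchanged here, so that measured step does not bear on the present change, and no other measured pair isolates it. With nothing to fix the direction, compound 3 is expected to land near compound 2, the step of a 1.4-fold higher number from compound 2 to compound 3 (0.14 log units; within the scatter) being the best guess with a wide band around it. Compound 3 is thus estimated at 40 nM in this assay, within a range of 12 nM to 130 nM.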

Compound 3, half-maximal inhibitory concentration: 27 nM
Compound 3: the middle estimate sits 1.5-fold (0.17 log units) above what was measured; measured number inside the range.
By their numbers in this assay, from the lowest: compound 1; then compounds 3 and 2 (each within the scatter of the next).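

In this assay, exchanging the group on this saturated chain carbon gives a 1.1-fold lower number from compound 2 to compound 3 (0.03 log units; within the scatter), so the two groups cannot be told apart here. In this pair, a carbon-only aromatic ring with no hydrogen-bond acceptor stands in for 5-fluoropyridin-2-yl, and the ring nitrogen and the fluorine both leave, yet the number stays within the scatter of compound 2. This says something about one exchange on one core only, and nothing measured here explains why the two groups read alike.

The compounds shown leave open whether the same exchange would read alike on the core of compound 1, which carries methyl where compound 2 and compound 3 carry fluoro. They also leave open how far this position accepts other groups, for example an amine or a carboxylic acid on the aromatic ring, or a saturated cyclohexyl ring in place of the aromatic ring.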